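The source may report more compounds than this note shows. Statements on the series, on what has been measured and on what is new or still open speak of the compounds shown alone.

Compound 1 `OC1CN(Cc2ccc(Br)cc2)CCC1N1CCN(c2ccccc2)CC1` — > 100 nM
Compound 2 `CCN1CCC(N2CCN(c3ccccc3)CC2)C(O)C1` — > 1000 nM
Compound 3 `OC1CCN(Cc2ccc(Br)cc2)CC1N1CCN(c2ccccc2)CC1` — > 100 nM

The three compounds were tested in an assay on PC-12 cells for displacement of a labelled ligand from vesicular acetylcholine transporter (Homo sapiens); a lower number here means a stronger inhibitor, a higher number a weaker inhibitor. In this assay compound 1 gives > 100 nM, which is a limit of the assay rather than a number. Compound 2 gives > 1000 nM, also a limit. Compound 3 gives > 100 nM, again a limit.

The change from compound 1 to compound 2 is methyl in place of 4-bromophenyl on a saturated chain carbon bound to an amine nitrogen in a ring. With both ends at a limit, the step that the two limits leave unreadable from compound 1 to compound 2 cannot be read.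

Compound 1 and compound 3 are built from the same atoms joined differently; the difference between the two cores is not broken down here.

Compound 4 `CCN1CCC(O)C(N2CCN(c3ccccc3)CC2)C1` has not yet been measured in this assay. It stands to compound 3 as compound 2 stands to compound 1, the same change at the same place: methyl in place of 4-bromophenyl on a saturated chain carbon bound to an amine nitrogen in a ring. Among the compounds with values here, two of the values shown sit at the limit of > 100 nM in this assay, at which 2 of the 3 values shown sit, and one at the limit of > 1000 nM in this assay, at which 1 of the 3 values shown sits, so no compound here has yet produced a readable number, and compound 4 is expected to follow the same course, most likely again returning only a limit. For compound 4 the expected value in this assay is 3000 nM, with a range from 800 nM to 12000 nM. The step this implies is estimated as a step that the limit leaves unreadable from compound 3 to compound 4.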

Compound 4, half-maximal inhibitory concentration: > 1000 nM
Compound 4 was reported as a limit; the forecaster's own chance of this, stated with the estimate: 85%; the middle value lies beyond the limit too.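

In this assay, within the data shown here, compound 3 and compound 4 are both reported only as limits of the assay, not as numbers, so the change from 4-bromophenyl to methyl between compound 3 and compound 4 gives no step that can be read. The compounds shown leave open how strongly any of them actually inhibits the transporter, and whether the bromine-bearing compounds differ from the methyl ones at all.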